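The compounds below may be only part of what the source reports. "The series", "measured", "known", "first", "only" and "open" are said of these compounds alone.

Compound 1 `N#CC1=C(N)Oc2c(c3nc4ccccc4nc3c3ccccc23)C12C(=O)N(Cc1cnnn1-c1ccc(F)cc1)c1ccccc12`: in a functional assay on MCF7 cells (Homo sapiens) for antiproliferative activity, read by MTT assay, with a stated time of 48 h (on this read-out lower numbers stand for stronger inhibition and higher numbers for weaker inhibition), compound 1 gives > 50000 nM, which is a limit of the assay and not a number.
Compound 2 `N#CC1=C(N)Oc2c(c3nc4ccccc4nc3c3ccccc23)C12C(=O)N(Cc1cnnn1-c1ccc(F)c(Cl)c1)c1ccccc12`: in this assay compound 2 gives > 50000 nM, again a limit of the assay.
Compound 3 `CCc1ccccc1-n1nncc1CN1C(=O)C2(C(C#N)=C(N)Oc3c(N)cc4nc5ccccc5nc4c32)c2ccccc21`: in this assay compound 3 gives 24600 nM.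

Compound 3 is the only one of the three with a measured number; the other two values are limits. The step from compound 1 to compound 2 is a step that the two limits leave unreadable from compound 1 to compound 2, and it cannot be read because both values sit at the limit of > 50000 nM in this assay, at which 2 of the 3 values shown sit. Going by the values given here, no measured step reaches compound 3 itself.

Compound 4 `N#CC1=C(N)Oc2c(N)cc3nc4ccccc4nc3c2C12C(=O)N(Cc1cnnn1-c1ccc(Cl)cc1Cl)c1ccccc12` differs from compound 3 by 2,4-dichlorophenyl in place of 2-ethylphenyl on an aromatic nitrogen. None of the measured steps concerns this change, so there is no shown step on which to build an expectation of its size or direction. Compound 4 keeps the rest of the structure of compound 3, so compound 3 is the only anchor, while the halogenated phenyl rings on compounds 1 and 2 are accompanied only by limits.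

Compound 4 is therefore expected to stay near its anchor, at a step of a 1.2-fold higher number from compound 3 to compound 4 (0.09 log units; within the scatter) from compound 3. The estimate for compound 4 in this assay is 30000 nM, within a range of 8000 nM to 60000 nM.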

Compound 4, half-maximal inhibitory concentration: > 50000 nM
Compound 4 was reported as a limit; the forecaster's own chance of this, stated with the estimate: 40%; middle value at least 1.6-fold (0.22 log units) away from the limit.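

In this assay compound 4 gives > 50000 nM, which is a limit of the assay and not a number. This gives the first readable step at the phenyl group on the aromatic nitrogen of the five-membered ring: 2,4-dichlorophenyl in place of 2-ethylphenyl is an at least 2.0-fold higher number from compound 3 to compound 4 (0.30 log units; that floor lies within the scatter), but this is only a floor, so the change is not shown to go beyond the scatter and its true size remains unknown. On the core of compound 3, a halogenated phenyl group at this position also ends at the limit, as the two halogenated phenyl compounds on the other core did: the limit of > 50000 nM in this assay, at which 3 of the 4 values shown sit.

From the compounds shown here alone, whether a 2-methylphenyl, a 4-methoxyphenyl or an unsubstituted phenyl group on that nitrogen would give a measurable number on the core of compound 3 stays open, as does whether the 2-ethyl group itself matters or whether a longer chain would serve as well. Going by these compounds, the part played by the amine on the core also stays open, for compounds 1 and 2 differ from compound 3 in more than one place and cannot be compared with it.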